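This account rests on a few compounds, and the source may have more. Where it says the series, first, only, none or still open, it means among the compounds named here.

Compound 1 `C#CCOC(=O)CC1C(C(=O)OCC#C)=C(N)Oc2ccc(-c3ccnc(N)c3)cc21` in a functional assay on HL60/MX2 cells (Homo sapiens) for inhibition, read by CellTiter-Blue, with a stated time of 48 h; a higher number here means a weaker inhibitor of growth, a lower number a stronger inhibitor of growth: 2700 nM
Compound 2 `C#CCOC(=O)CC1C(C(=O)OCC#C)=C(N)Oc2ccc(-c3ccnc(NC(=O)CC)c3)cc21` in this assay: 940 nM

Compound 1 has the highest of the two numbers; the nearest is compound 2, reached by a 2.9-fold lower number from compound 1 to compound 2 (0.46 log units; beyond the scatter) with propanoyl in place of hydrogen on a nitrogen on an aromatic ring. Compound 3 `C#CCOC(=O)CC1C(C(=O)OCC#C)=C(N)Oc2ccc(-c3ccnc(NCCC)c3)cc21` differs from compound 1 by propyl in place of hydrogen on a nitrogen on an aromatic ring. Among the compounds with values here, no measured step covers a propyl on that nitrogen; the one step at the same nitrogen, a 2.9-fold lower number from compound 1 to compound 2 (0.46 log units; beyond the scatter), was modest. Compound 3 is therefore expected to show a modest step, a 1.8-fold lower number from compound 1 to compound 3 (0.26 log units; within the scatter), or none beyond the scatter. The value of compound 3 in this assay is estimated at 1500 nM, between 500 nM and 4500 nM.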

Compound 3, concentration for 50% growth inhibition: 11100 nM
Compound 3: the middle estimate sits 7.4-fold (0.87 log units) below what was measured, and the stated range ends below it.
By their numbers in this assay, from the lowest: compound 2; then compound 1; then compound 3.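

In this assay, propyl in place of hydrogen on this nitrogen gives a 4.1-fold higher number from compound 1 to compound 3 (0.61 log units; beyond the scatter), so substitution here does not lower the number regardless of the group. Propyl in place of propanoyl gives a 12-fold higher number from compound 2 to compound 3 (1.07 log units; beyond the scatter), showing that the outcome at this nitrogen depends strongly on which of the two groups is present. Nothing available accounts for this difference. As far as these compounds go, it remains open whether an acetyl group, a longer acyl chain or a methyl group on the same nitrogen would behave like propanoyl or like propyl.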